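From cyclohexyl to naphthalen-2-yl on a shared core

The source may report more compounds than this note shows. Statements on the series, on what has been measured and on what is new or still open speak of the compounds shown alone.

Three compounds share one core and differ in a single group on a saturated chain carbon bound to two aromatic carbons. In a functional assay on A549 cells (Homo sapiens) for inhibition, read by MTT assay, with a stated time of 48 h (on this read-out lower numbers stand for stronger inhibition and higher numbers for weaker inhibition), compound 1 `COc1cccc(C(c2c[nH]c3ccc(Br)cc23)c2c[nH]c3ccc(Br)cc23)c1OC` gives 100000 nM, compound 2 `COc1ccc(OC)c(C(c2c[nH]c3ccc(Br)cc23)c2c[nH]c3ccc(Br)cc23)c1` gives 10000 nM and compound 3 `Brc1ccc2[nH]cc(C(c3c[nH]c4ccc(Br)cc34)C3CCCCC3)c2c1` gives 5500 nM. Compound 4 `Brc1ccc2[nH]cc(C(c3ccc4ccccc4c3)c3c[nH]c4ccc(Br)cc34)c2c1` carries naphthalen-2-yl in place of cyclohexyl on a saturated chain carbon bound to two aromatic carbons. The closest evidence is the swap between cyclohexyl and the dimethoxyphenyl groups: a 1.8-fold lower number from compound 2 to compound 3 (0.26 log units; within the scatter), yet an 18-fold lower number from compound 1 to compound 3 (1.26 log units; beyond the scatter). The two aromatic groups themselves differ widely, with a 10-fold lower number from compound 1 to compound 2 (1.00 log units; beyond the scatter). A small upward move in this assay is therefore expected, an estimated 1.8-fold higher number from compound 3 to compound 4 (0.26 log units; within the scatter). For compound 4 the estimated value is 10000 nM, with an expected range of 3000 nM to 40000 nM.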

Compound 4, half-maximal inhibitory concentration: 8500 nM
Estimate against measurement, compound 4: 1.2-fold (0.07 log units) above, and the stated range covers the measured number.
By their numbers in this assay, from the lowest: compounds 3, 4 and 2 (each within the scatter of the next); then compound 1.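

At this position in this assay, naphthalen-2-yl cannot be told apart from cyclohexyl, with a 1.5-fold higher number from compound 3 to compound 4 (0.19 log units; within the scatter), or from 2,5-dimethoxyphenyl, with a 1.2-fold lower number from compound 2 to compound 4 (0.07 log units; within the scatter). So a group with only carbon aromatic rings and one with a non-aromatic ring fall together here, and only 2,3-dimethoxyphenyl stands apart, with a 12-fold lower number from compound 1 to compound 4 (1.07 log units; beyond the scatter). Nothing available explains why compound 1 differs.

On these data alone, whether a group carrying an amine or a carboxylic acid would stay with compounds 2, 3 and 4 remains open. So does whether any group here could give a clearly lower number.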